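The compounds below may be only part of what the source reports. "The series", "measured", "known", "first", "only" and "open" are said of these compounds alone.

Measured so far in a toxicity assay on the whole organism with Rattus norvegicus as the target, at a dose of 400 mg/kg by the oral route; on this read-out higher numbers stand for a stronger effect at the one dose given and lower numbers for a weaker effect:

- compound 1 `COc1ccc(OCC2=NCCO2)cc1`: 15%
- compound 2 `Cc1ccccc1OCC1=NCCO1`: 40%
- compound 3 `Cc1ccc(OCC2=NCCO2)c(C)c1`: 18%

Compound 2 stands highest of the three numbers in this assay; compound 3 lies nearest, compound 1 furthest, and both gaps are beyond the scatter.

Compound 4 `Fc1ccccc1OCC1=NCCO1` is not yet measured. It differs from compound 2 in one place: fluoro in place of methyl on an aromatic carbon. Going by the values given here, no measured pair swaps methyl for fluoro, so no step bears on this change directly. Among the compounds with values here, the only single-place step, a number 22 percentage points lower from compound 2 to compound 3 (beyond the scatter), concerns a methyl added on an aromatic carbon, not one replaced, and so carries little weight here. With compound 2 at 40% as the only anchor, the expected step is a number 7 percentage points lower from compound 2 to compound 4 (within the scatter), a small move downward that may well lie within the scatter. Compound 4 is estimated at 33%, with a range from 12% to 55%.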

Compound 4, a percentage reported as activity, at one dose (the size of the read-out at that dose, not a potency): 20%
Beside the measured number, compound 4's estimate is 13 percentage points above it, and the stated range covers the measured number.
By their numbers in this assay, from the lowest: compounds 1, 3 and 4 (each within the scatter of the next); then compound 2.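

In this assay, fluoro in place of methyl on an aromatic carbon, ortho to a group of 7 heavy atoms, gives a number 20 percentage points lower from compound 2 to compound 4 (beyond the scatter) and so shows that the read-out responds to the group held at this position. Going by these compounds alone, the earlier step, a number 22 percentage points lower from compound 2 to compound 3 (beyond the scatter), came from adding a methyl while the methyl of compound 2 stayed in place; the new step is the first to exchange that methyl itself, and both single-place steps from compound 2 lead downward. Nothing at hand accounts for the drop on going from methyl to fluoro.

Open, as far as these compounds go, is whether methyl alone holds the higher number at this position, or whether a chloro, a methoxy or an amine on the same aromatic carbon would do likewise. Also open, from the compounds shown here alone, is how a fluoro on any other aromatic carbon of the ring would read.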